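Adding a Methyl to the Anilino Ring of Compound 3

A few compounds are considered here, and "the series" means these few. Any claim that something is new, unique, unknown or untested is made for them only; others in the source may bear on it.

Compound 3 `COc1cc(/C=C/C(=O)c2sc(Nc3ccccc3)nc2C)cc(OC)c1OC` is one of three measured members of this small series. In a functional assay on BGC-823 cells (Homo sapiens) for cytotoxicity, read by MTT assay (a lower number here means a stronger inhibitor, a higher number a weaker inhibitor), compound 3 gives > 25000 nM, which is a limit of the assay rather than a number. Compound 1 `COc1cc(/C=C/C(=O)c2sc(Nc3ccc(Cl)cc3)nc2C)cc(OC)c1OC` carries a chloro on the same ring. In this assay compound 1 gives > 25000 nM, again a limit. For the measured compounds named here, compound 2 `COc1cc(/C=C/C(=O)c2sc(Nc3ccc(F)c(Cl)c3)nc2C)cc(OC)c1OC` gives 9700 nM in this assay, the only finite value in the set. The two readable steps, an at least 2.5-fold lower number from compound 1 to compound 2 (0.41 log units; beyond the scatter) and an at least 2.5-fold higher number from compound 2 to compound 3 (0.41 log units; beyond the scatter), point the same way, while a step that the two limits leave unreadable from compound 1 to compound 3. The line the limit of > 25000 nM in this assay, at which 2 of the 3 values shown sit, shows where two of the three values rest.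

Compound 4 `COc1cc(/C=C/C(=O)c2sc(Nc3ccc(C)cc3)nc2C)cc(OC)c1OC` differs from compound 3 by methyl in place of hydrogen on an aromatic carbon. Going by the values given here, no measured step adds a methyl to this ring. The nearest comparison is a step that the two limits leave unreadable from compound 1 to compound 3, a step between two limits, and the larger moves appear only with the two-halogen ring of compound 2. Compound 4 is therefore expected to stay close to the limit, and the step that the limit leaves unreadable from compound 3 to compound 4 is expected to be small or not readable. The estimate for compound 4 in this assay is 30000 nM, within a range from 10000 nM to 90000 nM.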

Compound 4, half-maximal inhibitory concentration: > 25000 nM
Compound 4 gave a limit, no number (the forecaster's own chance of this, stated with the estimate: 70%); the middle value is on the limit's open side.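

In this assay compound 4 gives > 25000 nM, which is a limit of the assay and not a number, so a methyl on this aromatic carbon, para to a large group, does not bring the anilino ring of compound 3 to a finite value. For the compounds shown here, the one readable step, an at least 2.5-fold higher number from compound 2 to compound 4 (0.41 log units; beyond the scatter), shows that the 4-methylphenyl ring falls short of the 3-chloro-4-fluorophenyl ring by more than the scatter, while the steps linking compound 4 to compound 3 and to compound 1 cannot be read. With a single added carbon now tried alongside a single chloro, the only finite value still belongs to the two-halogen ring, and the series rests mostly at one limit: the limit of > 25000 nM in this assay, at which 3 of the 4 values shown sit.

On these data alone, how far compound 1, compound 3 and compound 4 lie beyond that limit stays unknown, so any real difference among hydrogen, chloro and methyl here stays hidden. Also open, as far as these compounds go, is whether the chloro or the fluoro of the two-halogen ring carries its effect alone, and whether a methoxy, a trifluoromethyl or an amine on this ring would give a finite value.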